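Amide nitrogen substituents on the shared core

A few compounds are considered here, and "the series" means these few. Any claim that something is new, unique, unknown or untested is made for them only; others in the source may bear on it.

Compound 3 `C=CC1=C(C(=O)Nc2ccccc2)C(c2ccc(OC)cc2)OC1` sits at the limit of > 100000 nM in a functional assay on SW480 cells (Homo sapiens) for cytotoxicity, read by MTT assay, with a stated time of 24 h (on this read-out higher numbers stand for weaker inhibition and lower numbers for stronger inhibition), which is a limit and not a number. Compound 2 `C=CC1=C(C(=O)NC(C)(C)C)C(c2ccc(OC)cc2)OC1` likewise sits at the limit of > 100000 nM. Compound 1 `C=CC1=C(C(=O)NCc2ccccc2)C(c2ccc(OC)cc2)OC1` gives 39500 nM. Two of the three values rest at the limit of > 100000 nM in this assay, at which 2 of the 3 values shown sit. The step of an at least 2.5-fold higher number from compound 1 to compound 3 (0.40 log units; beyond the scatter) bears directly on the change here, as does an at least 2.5-fold higher number from compound 1 to compound 2 (0.40 log units; beyond the scatter), while a step that the two limits leave unreadable from compound 2 to compound 3. Compound 4 `C=CC1=C(C(=O)NCc2ccc(Cl)cc2)C(c2ccc(OC)cc2)OC1` carries 4-chlorobenzyl in place of phenyl on an amide-type nitrogen; the 4-chlorobenzyl differs from the benzyl of compound 1 by the chlorine. The change largely reverses the benzyl-to-phenyl step, so a lower number is expected, estimated as an at least 3.3-fold lower number from compound 3 to compound 4 (0.52 log units; beyond the scatter). Compound 4 is therefore expected to give 30000 nM, in the range 10000 nM to 100000 nM.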

Compound 4, half-maximal inhibitory concentration: > 100000 nM
Compound 4 ended at the assay's limit (the forecaster's own chance of this, stated with the estimate: 25%); middle value at least 3.3-fold (0.52 log units) from the limit.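

In this assay, chloro in place of hydrogen on an aromatic carbon of the benzyl group gives an at least 2.5-fold higher number from compound 1 to compound 4 (0.40 log units; beyond the scatter), so the benzyl-type amide substituent alone does not secure a value within range. Compound 4 gives > 100000 nM, which is a limit and not a number, and its steps from compound 2 and compound 3 cannot be read. Compound 1 thus remains the only compound with a number, the others resting at: the limit of > 100000 nM in this assay, at which 3 of the 4 values shown sit.

Open, going by these compounds, is whether fluoro or methoxy in place of the chloro would return a number. Also open, on these data alone, is whether a longer chain such as 2-phenylethyl on the amide nitrogen would do so.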